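A few compounds are considered here, and "the series" means these few. Any claim that something is new, unique, unknown or untested is made for them only; others in the source may bear on it.

In a functional assay on A-375 cells (Homo sapiens) for antiproliferative activity, read by sulforhodamine B assay, with a stated time of 48 h (on this read-out higher numbers stand for weaker inhibition and lower numbers for stronger inhibition), three amides on the shared core differ only in chain length: compound 1 `CCCCCCCCCCCCCCNC(=O)[C@@H]1CNC(c2ccccc2)=N1` gives 7100 nM, compound 2 `CCCCCCCCCCCCCCCCNC(=O)[C@@H]1CNC(c2ccccc2)=N1` gives 10500 nM, and compound 3 `CCCCCCCCCCCCCCCCCCNC(=O)[C@@H]1CNC(c2ccccc2)=N1` gives 54300 nM. Compound 2 therefore stands level with compound 1, within the scatter, and lower than compound 3. The measured steps are a 1.5-fold higher number from compound 1 to compound 2 (0.17 log units; within the scatter), within the scatter, and the modest 5.2-fold higher number from compound 2 to compound 3 (0.71 log units; beyond the scatter) and a 7.6-fold higher number from compound 1 to compound 3 (0.88 log units; beyond the scatter).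

Compound 4 `CCCCCCCCCCCCCCCCNC(=O)[C@@H]1CNC(c2cc(OC)c(OC)c(OC)c2)=N1` keeps the chain of compound 2 and changes 3,4,5-trimethoxyphenyl in place of phenyl on a carbon with a double bond to nitrogen. All measured steps concern the chain, so none bears directly on this change, and no direction is supported. No shift beyond the scatter is expected in this assay. The expected change is a 1.2-fold lower number from compound 2 to compound 4 (0.07 log units; within the scatter). Compound 4 is estimated at 9000 nM, with an expected range of 3000 nM to 27000 nM.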

Compound 4, half-maximal inhibitory concentration: 4100 nM
Compound 4: middle estimate off by 2.2-fold (0.34 log units), on the high side; measured number inside the range.
By their numbers in this assay, from the lowest: compounds 4, 1 and 2 (each within the scatter of the next, the first and the last beyond it); then compound 3.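

In this assay, the position on a carbon with a double bond to nitrogen proves responsive: 3,4,5-trimethoxyphenyl in place of phenyl gives a 2.6-fold lower number from compound 2 to compound 4 (0.41 log units; beyond the scatter), with the chain of compound 2 kept. Within the data shown here, this is the first step away from the chain, and it goes towards stronger inhibition, whereas the chain steps beyond the scatter go towards weaker inhibition. No measured evidence gives a reason for this shift.

Open: whether a single methoxy group, a hydroxyl or an amine on the phenyl ring gives a similar step, and whether 3,4,5-trimethoxyphenyl acts likewise on the chains of compound 1 and compound 3.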